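Removing a propyl from the chain of compound 3

The source may report more compounds than this note shows. Statements on the series, on what has been measured and on what is new or still open speak of the compounds shown alone.

Values in a physicochemical assay for lipophilicity, measured as octanol-water partition; on this read-out lower numbers stand for lower lipophilicity and higher numbers for higher lipophilicity:
Compound 1 `CCCCCc1cn(C/C=C(\C)CCC=C(C)C)nn1`: 5.45
Compound 2 `CCCc1cn(C/C=C(\C)CC/C=C(\C)CCC=C(C)C)nn1`: 6.5
Compound 3 `CCCCCCCCc1cn(C/C=C(\C)CC/C=C(\C)CCC=C(C)C)nn1`: 8.76
Compound 4 `CCCCCc1cn(C/C=C(\C)CC/C=C(\C)CCC=C(C)C)nn1`: not yet measured

Compound 3, at 8.76, has the highest of the three numbers in this assay. Its gaps to the other two lie beyond the scatter: compound 2 stands at 6.5 and compound 1 at 5.45.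

Compound 4 differs from compound 3 by a single change (hydrogen in place of propyl on a saturated chain carbon, five bonds along the chain from an aromatic carbon): hydrogen in place of propyl on a saturated chain carbon, five bonds along the chain from an aromatic carbon. The same difference reads hexyl to propyl when cut one bond further out.

Among the measured compounds shown here, only one measured step bears on this change: a number 2.26 log units higher from compound 2 to compound 3 (beyond the scatter). That large step came with pentyl in place of hydrogen on the same chain, three bonds along the chain from an aromatic carbon. The new change runs the other way and takes away only propyl, so a fall of smaller size is expected. For the measured compounds named here, no measured step connects compound 1 to the others, so it sets no step size here.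

The expected change in this assay is a number 1.36 log units lower from compound 3 to compound 4 (beyond the scatter), which would lie beyond the scatter. Compound 4 is estimated at 7.4, with an expected range from 7.05 to 7.75.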

Compound 4, partition coefficient: 7.5
Estimate against measurement, compound 4: 0.10 log units below, within the range that was stated.
By their numbers in this assay, from the lowest: compound 1; then compound 2; then compound 4; then compound 3.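

In this assay, compound 4 gives the series on this chain a middle point, and both parts of the earlier large step hold up: shortening the chain by taking away propyl gives a number 1.26 log units lower from compound 3 to compound 4 (beyond the scatter), while the ethyl that separates the pentyl from the propyl chain gives a number 1.00 log units higher from compound 2 to compound 4 (beyond the scatter). Among compound 2, compound 4 and compound 3, the number therefore rises with each longer chain, and none of the three goes against this order, so the earlier step was not the work of the far end of the octyl chain alone. Among the compounds shown here, compound 4 also ties compound 1 into the set for the first time: with the same pentyl chain, 3-methylbut-2-en-1-yl in place of hydrogen on a saturated chain carbon bound to a double-bonded chain carbon gives a number 2.05 log units higher from compound 1 to compound 4 (beyond the scatter), so the other end of the molecule moves this number as well. Nothing shown here accounts for the size of these steps.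

Going by these compounds, whether a chain longer than the octyl of compound 3 would carry the rise further remains open. So does the effect of an amine or a carboxylic acid at the end of the pentyl chain.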